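This account rests on a few compounds, and the source may have more. Where it says the series, first, only, none or still open, it means among the compounds named here.

Compound 1 `CN1C[C@H]2C=C(c3cccnc3)C[C@H](C2)C1` gives 11% in an in vitro functional assay on SH-EP1 cells for agonist activity at Neuronal acetylcholine receptor; alpha4/beta2 (Homo sapiens), read by FLIPR and calcium flux; a higher number here means a larger maximal response, a lower number a smaller maximal response. Compound 2 `Fc1ccc(C2=CC3CNCC(C2)C3)cn1` gives 136% in this assay. Compound 3 `C1=C(c2cccnc2)C[C@H]2CNC[C@@H]1C2` gives 129% in this assay.

Compound 3 and compound 1 differ in one place only, (methyl in place of hydrogen on an amine nitrogen in a ring), and this single change produced a number 118 percentage points lower from compound 3 to compound 1 (beyond the scatter). Compound 4 `CN1CC2C=C(c3ccc(F)nc3)CC(C2)C1` is not yet measured; it stands to compound 2 exactly as compound 1 stands to compound 3, since the change is again (methyl in place of hydrogen on an amine nitrogen in a ring), at a place described in the same words for both pairs. The difference between the core of compound 2 and the core of compound 3 is not broken down here, but their values in this assay lie close together. Because the same change gave a number 118 percentage points lower from compound 3 to compound 1 (beyond the scatter), a step of similar size is expected here, estimated as a number 116 percentage points lower from compound 2 to compound 4 (beyond the scatter). Compound 4 is therefore estimated to reach 20% in this assay, with a likely range from 5% to 45%.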

Compound 4, largest response reached (reported as percent of maximum), in percent of the reference or control that the assay uses: 9.4%
The estimate for compound 4 lay 10.6 percentage points above the measured number; measured number inside the range.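

In this assay, putting methyl in place of hydrogen on the amine nitrogen in the ring gave a number 126.6 percentage points lower from compound 2 to compound 4 (beyond the scatter). Going by these compounds alone, the same change therefore had a step of much the same size on both cores: the same change on two cores in this assay, a number 118 percentage points lower (beyond the scatter) from compound 3 to compound 1 and a number 126.6 percentage points lower (beyond the scatter) from compound 2 to compound 4, 8.6 percentage points apart, within the scatter of two such steps These are only two pairs, so they show that the step repeated on these two cores, not that it is a general rule for the series, and they do not show why methyl has this effect.

Only hydrogen and methyl stand on this nitrogen in the compounds shown. As far as these compounds go, what ethyl or a longer chain would do there remains open, as does whether the step holds on other cores.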